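Swapping a triazole for piperidine on the propyl chain

The source may report more compounds than this note shows. Statements on the series, on what has been measured and on what is new or still open speak of the compounds shown alone.

Compound 1 `Cn1cc(C2=C(c3nn(CCCn4cncn4)c4ncccc34)C(=O)NC2=O)c2ccccc21` was tested in a functional assay on A549 cells (Homo sapiens) for antiproliferative activity, read by MTT assay, with a stated time of 48 h; on this read-out higher numbers stand for weaker inhibition and lower numbers for stronger inhibition. In this assay compound 1 gives only a limit, > 100000 nM. Compound 3 `Cn1cc(C2=C(c3nn(CCCn4ccnc4)c4ncccc34)C(=O)NC2=O)c2ccccc21` likewise returns only a limit in this assay, > 100000 nM. The step that the two limits leave unreadable from compound 1 to compound 3 cannot be sized, because both values sit at the limit of > 100000 nM in this assay, at which 2 of the 3 values shown sit. For the measured compounds named here, compound 2 `Cn1cc(C2=C(c3nn(CCCN4CCCCC4)c4ncccc34)C(=O)N(c3ccc(Cl)cc3)C2=O)c2ccccc21` gives 28700 nM in this assay; it carries the piperidin-1-yl group but also a different substituent on the imide nitrogen, so no single step joins it to compound 1, and its value shows only that a piperidin-1-yl member of this set can give a measurable number.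

Compound 4 `Cn1cc(C2=C(c3nn(CCCN4CCCCC4)c4ncccc34)C(=O)NC2=O)c2ccccc21` has not yet been measured. It differs from compound 1 by piperidin-1-yl in place of 1H-1,2,4-triazol-1-yl on a saturated chain carbon, three bonds along the chain from an aromatic nitrogen. Going by the values given here, no measured step bears directly on this change: the one step recorded from compound 1 has no readable size, and compound 2 differs in a second place. For compound 4 the step is therefore expected to be an at least 2.0-fold lower number from compound 1 to compound 4 (0.30 log units; that floor lies within the scatter), a move toward a measurable number rather than a large gain. Compound 4 is estimated to give about 50000 nM in this assay, with a likely range from 12000 nM to 150000 nM.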

Compound 4, half-maximal inhibitory concentration: > 100000 nM
Compound 4 ended at the assay's limit; the forecaster's own chance of this, stated with the estimate: 40%; middle value at least 2.0-fold (0.30 log units) away from the limit.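

In this assay, a piperidin-1-yl group on the propyl chain does not by itself bring a compound with the amide hydrogen to a measurable number. Compound 4 is a limit, as are compound 1 and compound 3, so the steps among these three cannot be read: the limit of > 100000 nM in this assay, at which 3 of the 4 values shown sit.

For the compounds shown here, the one readable step comes from placing hydrogen instead of 4-chlorophenyl on the amide-type nitrogen in a ring, which gives an at least 3.4-fold higher number from compound 2 to compound 4 (0.54 log units; beyond the scatter). In this pair, the measurable value therefore goes with the 4-chlorophenyl group and not with the piperidin-1-yl group alone.

The compounds shown leave open whether 4-chlorophenyl on that nitrogen would also give a measurable number with 1H-1,2,4-triazol-1-yl or 1H-imidazol-1-yl at the chain end. They also leave open whether a simple methyl or benzyl group on that nitrogen, or a morpholin-4-yl group or a longer chain on the other side of the molecule, would give a measurable number.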